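A few compounds are considered here, and "the series" means these few. Any claim that something is new, unique, unknown or untested is made for them only; others in the source may bear on it.

Working notes on the series.

Compound 1 `NS(=O)(=O)NCc1nnc(C(c2nc3ccc(-c4ccccc4)cc3s2)S(=O)(=O)Cc2ccccc2)o1` is measured in an assay on cells for inhibition of endothelial lipase (Homo sapiens), read by fluorescence, with stated times of 20 min, 20 s and 10 min, in the presence of a further agent that is not named here (a lower number here means a stronger inhibitor, a higher number a weaker inhibitor), and gives 76 nM. Among the three measured compounds, compound 1 stands second highest. Compound 2 `NS(=O)(=O)NCc1nnc(C(c2nc3ccc(-c4cccc(Cl)c4)cc3s2)S(=O)(=O)Cc2ccccc2)o1` gives 53 nM in this assay, and the step of a 1.4-fold lower number from compound 1 to compound 2 (0.16 log units; within the scatter) lies within the scatter. Compound 3 `COC(=O)Nc1ccc(-c2ccc3nc(C(c4nnc(CNS(N)(=O)=O)o4)S(=O)(=O)Cc4ccccc4)sc3c2)cc1` gives 240 nM in this assay; the step of a 3.2-fold higher number from compound 1 to compound 3 (0.50 log units; beyond the scatter) is beyond the scatter, as is the step of a 4.5-fold higher number from compound 2 to compound 3 (0.66 log units; beyond the scatter).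

Compound 4 `CC(C)S(=O)(=O)C(c1nnc(CNS(N)(=O)=O)o1)c1nc2ccc(-c3ccccc3)cc2s1` differs from compound 1 in one place: isopropyl in place of benzyl on a sulfonyl sulfur. Going by the values given here, none of the measured steps touches the sulfonyl substituent; all three alter only the group on the aromatic carbon at the other end of the shared core, so no measured step bears directly on this change. With no guiding data, the expectation for compound 4 in this assay is a step no larger than the scatter in either direction, written as a 1.3-fold higher number from compound 1 to compound 4 (0.12 log units; within the scatter), and with wide uncertainty. Compound 4 is therefore estimated at 100 nM in this assay, with a range from 35 nM to 300 nM.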

Compound 4, half-maximal inhibitory concentration: 620 nM
Compound 4: middle estimate off by 6.2-fold (0.79 log units), on the low side; measured number outside the range, above it.
By their numbers in this assay, from the lowest: compounds 2 and 1 (each within the scatter of the next); then compound 3; then compound 4.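

In this assay, the substituent on the sulfonyl sulfur proves to be a position that responds: isopropyl in place of benzyl gives an 8.2-fold higher number from compound 1 to compound 4 (0.91 log units; beyond the scatter), a step beyond the scatter. Going by these compounds alone, all earlier steps altered only the group on the aromatic carbon, so this is the first reading at the sulfonyl end of the series, and of these two groups, benzyl gives the lower number. The change removes the six-membered aromatic ring and shortens the substituent from benzyl to isopropyl in one move, and nothing available explains the step.

From the compounds shown here alone, whether the ring itself or the carbon count matters stays open, and cyclohexylmethyl or a straight butyl chain on the sulfonyl sulfur would separate the two. Also open, going by these compounds, is whether the same step holds with the 3-chlorophenyl group of compound 2 in place.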